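The compounds below may be only part of what the source reports. "The series", "measured", "known", "first", "only" and "open" are said of these compounds alone.

The shared core is examined here in a functional assay (strain AB) with Danio rerio as the target, read by microscopy, with a stated time of 1 h; a lower number here means that less compound is needed, a higher number that more compound is needed for the effect. Going by the values given here, compound 1, `CCN1CCc2c(sc(NC(=O)Nc3ccccc3)c2C(N)=O)C1`, is the one member without a number: in this assay compound 1 reaches only the limit of > 25000 nM. Compound 2, `CN1CCc2c(sc(NC(=O)Nc3ccc(Cl)cc3)c2C(N)=O)C1`, gives 4700 nM in this assay. Compound 2 thus holds the only number shown, while compound 1 sits at the limit described by the limit of > 25000 nM in this assay, at which 1 of the 2 values shown sits; the two differ in more than one place, so their values only stand side by side and no step between them is counted.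

Compound 3, `CC(C)CN1CCc2c(sc(NC(=O)Nc3ccc(Cl)cc3)c2C(N)=O)C1`, has not yet been tested. It differs from compound 2 by isopropyl in place of hydrogen on a saturated chain carbon bound to an amine nitrogen in a ring. Among the compounds with values here, no step between measured compounds matches this change, so the expectation rests on compound 2 alone. Within the data shown here, the only nearby information is that compound 1, with a longer chain on that nitrogen and an unsubstituted phenyl, reached only the limit. Compound 3 is therefore expected to sit near compound 2 or somewhat weaker, a step from compound 2 to compound 3 of about a 1.5-fold higher number from compound 2 to compound 3 (0.17 log units; within the scatter). The estimate for compound 3 in this assay is 7000 nM, within a range from 1500 nM to 25000 nM.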

Compound 3, half-maximal effective concentration: 4510 nM
The estimate for compound 3 lay 1.6-fold (0.19 log units) above the measured number; the measured number falls inside the stated range.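

In this assay, isopropyl in place of hydrogen on a saturated chain carbon bound to an amine nitrogen in a ring, the same difference as methyl to isobutyl, gives a 1.0-fold lower number from compound 2 to compound 3 (0.02 log units; within the scatter). Going by these compounds alone, this is the first step that can be counted, and it shows that compound 2 and compound 3, which differ only at this position, cannot be told apart in this read-out, so the larger isobutyl group is tolerated here without a measurable loss. Compound 1 remains the one member without a number, and its value is a limit: the limit of > 25000 nM in this assay, at which 1 of the 3 values shown sits.

Compound 1 differs from compound 2 and from compound 3 in more than one place, so the compounds shown do not tell whether its limit goes with the group on the ring nitrogen or with the unsubstituted phenyl. From the compounds shown here alone, it also remains open whether this position would accept groups of another kind as well, such as a longer chain, a chain ending in an amine or a carboxylic acid, since only methyl and isobutyl can be compared here.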